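The compounds below may be only part of what the source reports. "The series", "measured", "known", "first", "only" and "open" are said of these compounds alone.

Measured so far in a functional assay on K562 cells (Homo sapiens), read by MTT assay, with a stated time of 72 h; a higher number here means a weaker inhibitor, a lower number a stronger inhibitor:
compound 1 `COc1ncnc2c1c(-c1cc3ccccc3o1)cn2[C@@H]1O[C@H](CO)[C@@H](O)[C@H]1O` gives 13100 nM.
compound 3 `COc1ncnc2c1c(-c1ccco1)cn2[C@@H]1O[C@H](CO)[C@@H](O)[C@H]1O` gives 380 nM.
compound 2 `Nc1nc(N)c2c(-c3cc4ccccc4o3)cn([C@@H]3O[C@H](CO)[C@@H](O)[C@H]3O)c2n1` gives only a limit of > 20000 nM.

Compound 1 and compound 2 carry different cores; how they differ is not broken down here. Within the core of compound 1, the change furan-2-yl in place of 1-benzofuran-2-yl on an aromatic carbon produced a 34-fold lower number from compound 1 to compound 3 (1.54 log units; beyond the scatter). Compound 4 `Nc1nc(N)c2c(-c3ccco3)cn([C@@H]3O[C@H](CO)[C@@H](O)[C@H]3O)c2n1` carries the same change on the core of compound 2: furan-2-yl in place of 1-benzofuran-2-yl on an aromatic carbon, with the surroundings of the place described in identical words, so it is the same change. For compound 2 only the limit of > 20000 nM in this assay, at which 1 of the 3 values shown sits, is known, so the starting point is uncertain. Compound 4 is expected to show a step of an at least 6.6-fold lower number from compound 2 to compound 4 (0.82 log units; beyond the scatter), resting on the step of a 34-fold lower number from compound 1 to compound 3 (1.54 log units; beyond the scatter). The estimate for compound 4 in this assay is 3000 nM, between 500 nM and 20000 nM.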

Compound 4, half-maximal inhibitory concentration: > 20000 nM
Compound 4 was reported as a limit; the forecaster's own chance of this, stated with the estimate: 20%; middle value at least 6.6-fold (0.82 log units) away from the limit.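

Compound 2 and compound 4 are both reported only as a limit in this assay, so no step between them can be read: the limit of > 20000 nM in this assay, at which 2 of the 4 values shown sit.

The compounds shown leave open whether furan-2-yl in place of 1-benzofuran-2-yl changes the number at all on the core of compound 2.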